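Triazole nitrogen substituent: aryl replaced by benzyl

The source may hold more compounds than are shown below. What is called first, only, known or untested is meant among the compounds shown, and "the series" means these compounds.

Compound 3 `COc1ccc(-n2cc(CNC(=O)c3cccc4c3cnn4C(C)C)nn2)cc1` stands at a limit of the assay: in a functional assay on MGC-803 cells (Homo sapiens) for inhibition, read by MTT assay, with a stated time of 72 h (a higher number here means a weaker inhibitor, a lower number a stronger inhibitor), compound 3 gives > 40000 nM, which is a limit and not a number. Compound 1 `CC(C)n1ncc2c(C(=O)NCc3cn(-c4ccc([N+](=O)[O-])cc4)nn3)cccc21` is likewise at a limit, giving > 40000 nM in this assay. Compound 2 `Cc1ccccc1-n1cc(CNC(=O)c2cccc3c2cnn3C(C)C)nn1` also gives > 40000 nM in this assay, again a limit. All three values shown sit at the limit of > 40000 nM in this assay, at which 3 of the 3 values shown sit. The steps among these compounds, a step that the two limits leave unreadable from compound 1 to compound 2, a step that the two limits leave unreadable from compound 1 to compound 3 and a step that the two limits leave unreadable from compound 2 to compound 3, are not readable in size. Compound 4 `CC(C)n1ncc2c(C(=O)NCc3cn(Cc4ccccc4)nn3)cccc21` is the next member and differs from compound 3 in one place: benzyl in place of 4-methoxyphenyl on an aromatic nitrogen. The measured steps that bear on this change are all swaps of the group on the same aromatic nitrogen, and none of them reads as a step of any size, so no move beyond the scatter in this assay can be expected in either direction. Compound 4 is expected to give 60000 nM in this assay, within a range from 20000 nM to 200000 nM, most likely reported once more as a limit. The step this estimate means, a step that the limit leaves unreadable from compound 3 to compound 4, is expected to carry no readable size.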

Compound 4, half-maximal inhibitory concentration: 14300 nM
Beside the measured number, compound 4's estimate is 4.2-fold (0.62 log units) above it; the measured number lies below the stated range.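

In this assay, a change on this aromatic nitrogen can now be read: benzyl in place of 4-methoxyphenyl gives an at least 2.7-fold lower number from compound 3 to compound 4 (0.44 log units; beyond the scatter), benzyl in place of 2-methylphenyl gives an at least 2.7-fold lower number from compound 2 to compound 4 (0.44 log units; beyond the scatter), and benzyl in place of 4-nitrophenyl gives an at least 2.7-fold lower number from compound 1 to compound 4 (0.44 log units; beyond the scatter). Among the compounds shown, benzyl is the only group off the limit, while the steps among the three aryl compounds cannot be read. Each of the new steps is a minimum and not a full size, since compounds 1, 2 and 3 each stand at a limit: the limit of > 40000 nM in this assay, at which 3 of the 4 values shown sit.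

As far as these compounds go, how far compounds 1, 2 and 3 truly lie from compound 4 stays open. Also open, from the compounds shown here alone, is how a longer chain such as phenethyl, or a cyclohexylmethyl group, would read on this nitrogen.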